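The source may hold more compounds than are shown below. What is called first, only, known or untested is meant among the compounds shown, and "the series" means these compounds.

In an ADME assay on MT4 cells (Homo sapiens) for cytotoxicity, read by MTT assay, with a stated time of 5 days (on this read-out lower numbers stand for higher toxicity in this test and higher numbers for lower toxicity in this test), compound 1 `Cc1cc(C)cc(S(=O)(=O)c2c(C(=O)NC3CN(S(C)(=O)=O)C3)[nH]c3ccc(Cl)cc23)c1` gives > 252000 nM as its reading, which is a limit and not a number. Compound 2 `Cc1cc(C)cc(S(=O)(=O)c2c(C(=O)NC3CN(Cc4ccccc4F)C3)[nH]c3ccc(Cl)cc23)c1` gives > 238000 nM as its reading, which is also a limit and not a number. Going by the values given here, compound 2 therefore stands only at a limit, and the one other value shown is a limit too.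

Among the compounds with values here, compound 3 `Cc1cc(C)cc(S(=O)(=O)c2c(C(=O)NS(C)(=O)=O)[nH]c3ccc(Cl)cc23)c1` differs from compound 2 by having methylsulfonyl in place of 1-(2-fluorobenzyl)azetidin-3-yl on an amide-type nitrogen as its single structural change. Within the data shown here, the only measured guide is a step that the two limits leave unreadable from compound 1 to compound 2 and it concerns 2-fluorobenzyl in place of methylsulfonyl on an amine nitrogen in a ring, so it offers no size to carry forward. The expectation in this assay is therefore no change beyond the scatter in either direction, and compound 3 may well be reported as a limit too. The expected outcome is a step that the limit leaves unreadable from compound 2 to compound 3 in this estimate. For compound 3 the estimated half-maximal cytotoxic concentration is 240000 nM with an expected range from 70000 nM to 290000 nM at its ends.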

Compound 3, half-maximal cytotoxic concentration: 40200 nM
Beside the measured number, compound 3's estimate is 6.0-fold (0.78 log units) above it; measured number outside the range, below it.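

In this assay, the group on the amide-type nitrogen turns out to matter: methylsulfonyl in place of 1-(2-fluorobenzyl)azetidin-3-yl gives an at least 5.9-fold lower number from compound 2 to compound 3 (0.77 log units; beyond the scatter), and a lower number here means higher toxicity in this test. The same entering group in place of 1-(methylsulfonyl)azetidin-3-yl gives an at least 6.2-fold lower number from compound 1 to compound 3 (0.79 log units; beyond the scatter), so the change points the same way from both starting compounds, although the step between those two starting compounds cannot be read. Compound 3 is also the only compound shown whose reading is a number and not a limit, so this change is the first to bring a measurable toxicity into view in this short series.

As far as these compounds go, the true size of the step to compound 3 stays open, because compound 2 stands at a limit and gives only a minimum for that step: the limit of > 238000 nM in this assay, at which 1 of the 3 values shown sits. From the compounds shown here alone, whether the change follows from methylsulfonyl itself or from the loss of the four-membered ring also stays open, and a plain methyl group or a longer carbon chain on this amide-type nitrogen would help to separate the two.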